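The source may report more compounds than this note shows. Statements on the series, on what has been measured and on what is new or still open speak of the compounds shown alone.

Working notes on the series.

Of the compounds shown here, two have numbers so far. Compound 1 `CC(C)(C)[C@H]1CC[C@H](N(Cc2ccc(C(=O)NCCC(=O)O)cc2)C(=O)Nc2ccc(OCC3CC3)cc2)CC1` gives, in an in vitro assay on BHK cells for inhibition of Glucagon receptor (Homo sapiens) (a higher number here means a weaker inhibitor, a lower number a stronger inhibitor), 140 nM. Compound 2 `CCCCC(CC)N(Cc1ccc(C(=O)NCCC(=O)O)cc1)C(=O)Nc1ccc(OC(F)(F)F)cc1` gives in this assay 141 nM. Compound 2 thus holds the highest of the two numbers, but its nearest neighbour is compound 1 at a gap that lies within the usual scatter, so the two stand together rather than apart, and no order between them can be read from the data.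

Going by the values given here, the next compound, compound 3 `O=C(O)CCNC(=O)c1ccc(CN(C(=O)Nc2ccc(OC(F)(F)F)cc2)C2CCC3(CC2)OCCO3)cc1`, has no measurement yet. It differs from compound 2 in one place (a group of 10 heavy atoms (8 carbon, 2 oxygen; one five-membered non-aromatic ring with 2 hetero atoms, one six-membered non-aromatic ring of carbon only) in place of a group of 7 heavy atoms (7 carbon; no ring), on an amide-type nitrogen), the change sitting on an amide-type nitrogen whose other neighbours are a carbonyl carbon and a saturated chain carbon. No step between measured compounds of this kind is available, so the size of the effect cannot be anchored on a shown pair; compound 1 and compound 2 only show that two different groups on that nitrogen give numbers that agree within the scatter.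

The expectation for compound 3 is a modest step toward a weaker inhibitor, a 2.1-fold higher number from compound 2 to compound 3 (0.33 log units; beyond the scatter), which may or may not clear the scatter. The estimate for compound 3 in this assay is 300 nM, with a range from 80 nM to 1200 nM.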

Compound 3, half-maximal inhibitory concentration: 1210 nM
Compound 3: middle estimate off by 4.0-fold (0.61 log units), on the low side; measured number above the stated range.
By their numbers in this assay, from the lowest: compounds 1 and 2 (each within the scatter of the next); then compound 3.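

Going by these compounds alone, the amide-type nitrogen that carries the 1-ethylpentyl group in compound 2 is not indifferent to what sits on it: in this assay the exchange for the group with one five-membered non-aromatic ring with 2 hetero atoms and one six-membered non-aromatic ring of carbon only gives an 8.6-fold higher number from compound 2 to compound 3 (0.93 log units; beyond the scatter), the only step on hand at this place and one beyond the scatter. The agreement of the two earlier numbers therefore does not extend to every group on this nitrogen. The change alters several things at once, the ring count, the heavy-atom count and the hydrogen-bond acceptors, and no measurement on hand bears on what lies behind the higher number.

Still open is whether the higher number goes with the two oxygen atoms of the five-membered ring or with the ring frame as a whole, since the compounds shown do not separate the two. A plain cyclohexyl group on this nitrogen, or a ketone or a hydroxyl group on the six-membered ring, with the rest of compound 3 kept, would bear directly on that question.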